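Quinone for hydroquinone on the pyrazole series

The source may hold more compounds than are shown below. What is called first, only, known or untested is meant among the compounds shown, and "the series" means these compounds.

Compound 1 `Oc1ccc(O)c(-c2cc(-c3ccc(Cl)cc3)nn2-c2ccccc2)c1` gives 3430 nM in a functional assay on cells (Leukemia cell, Homo sapiens) for cytotoxicity, read by sulforhodamine B assay, with a stated time of 48 h; on this read-out higher numbers stand for weaker inhibition of growth and lower numbers for stronger inhibition of growth. Compound 3 `O=C1C=CC(=O)C(c2cc(-c3ccc(Cl)cc3)nn2-c2ccccc2)=C1` carries the change a group of 8 heavy atoms (6 carbon, 2 oxygen; one six-membered non-aromatic ring of carbon only) in place of a group of 8 heavy atoms (6 carbon, 2 oxygen; one six-membered aromatic ring of carbon only), on an aromatic carbon and in this assay compound 3 gives 27800 nM, so the change made an 8.1-fold higher number from compound 1 to compound 3 (0.91 log units; beyond the scatter). Compound 2 `CC(=O)NS(=O)(=O)c1ccc(-n2nc(-c3ccccc3)cc2-c2cc(O)ccc2O)cc1` has a different core; how its core differs from that of compound 1 is not broken down here. In this assay compound 2 gives 93600 nM, the highest of the three numbers, with compound 3 nearest and compound 1 furthest.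

Compound 4 `CC(=O)NS(=O)(=O)c1ccc(-n2nc(-c3ccccc3)cc2C2=CC(=O)C=CC2=O)cc1` is not yet measured. It differs from compound 2 by a group of 8 heavy atoms (6 carbon, 2 oxygen; one six-membered non-aromatic ring of carbon only) in place of a group of 8 heavy atoms (6 carbon, 2 oxygen; one six-membered aromatic ring of carbon only), on an aromatic carbon. Within the data shown here, this is the same kind of change as the one from compound 1 to compound 3, but the surroundings of the place are not identical: in compound 4 the changed carbon is next to the ring atom that bears a large group and two ring bonds from the ring atom that bears a phenyl group, whereas in compound 3 it is next to the ring atom that bears a phenyl group and two ring bonds from the ring atom that bears a 4-chlorophenyl group.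

The expectation for compound 4 rests on one measured step only, that from compound 1 to compound 3 of an 8.1-fold higher number from compound 1 to compound 3 (0.91 log units; beyond the scatter), applied to the starting value of compound 2 of 93600 nM. On that basis the step from compound 2 to compound 4 in this assay is expected to be a 4.3-fold higher number from compound 2 to compound 4 (0.63 log units; beyond the scatter). Compound 4 is therefore expected to give about 400000 nM in this assay, with a range from 100000 nM to 1500000 nM.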

Compound 4, concentration for 50% growth inhibition: 57800 nM
Estimate against measurement, compound 4: 6.9-fold (0.84 log units) above; the whole stated range lies above it.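

In this assay, among these compounds, the exchange of the 2,5-dihydroxyphenyl group for the non-aromatic six-membered carbon ring gives a 1.6-fold lower number from compound 2 to compound 4 (0.21 log units; within the scatter), so on this core the change leaves no step that can be told apart from the usual scatter of repeated measurements. The size of the change therefore does not carry over from one core to the other, and a step measured on one core is a poor guide to the same exchange on the other: the same change on two cores in this assay, an 8.1-fold higher number (0.91 log units; beyond the scatter) from compound 1 to compound 3 and a 1.6-fold lower number (0.21 log units; within the scatter) from compound 2 to compound 4, 13-fold (1.12 log units) apart, beyond the scatter of two such steps What this does not show is which feature of the cores sets the gap, since the two cores differ in more than one place, and two pairs of compounds give no rule for the series as a whole.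

Going by these compounds, it remains open whether the step follows the 4-chlorophenyl group, the large group carried by compound 2 and compound 4, or both together, and a core with only one of these would separate them. On these data alone, it also remains open how the same exchange reads with a carboxylic acid or an amine in place of the large group, and whether the gap between the two steps holds in other cell types.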